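The source may report more compounds than this note shows. Statements on the series, on what has been measured and on what is new or still open speak of the compounds shown alone.

Three compounds share one core and differ only in the group on a saturated chain carbon bound to an amide-type nitrogen. Compound 1 `CCN(Cc1cccc(OC)c1)C(=O)C1CCN(S(=O)(=O)c2ccc3cn[nH]c3c2)CC1` carries a 3-methoxyphenyl there, compound 2 `CCN(Cc1cccc(C)c1)C(=O)C1CCN(S(=O)(=O)c2ccc3cn[nH]c3c2)CC1` a 3-methylphenyl and compound 3 `CCN(Cc1ccccc1C)C(=O)C1CCN(S(=O)(=O)c2ccc3cn[nH]c3c2)CC1` a 2-methylphenyl. In a functional assay on CHO cells for positive allosteric modulation of muscarinic acetylcholine receptor M5 (Homo sapiens), read by calcium flux (on this read-out higher numbers stand for larger maximal responses and lower numbers for smaller maximal responses), compound 1 gives 85%, compound 2 gives 78% and compound 3 gives 103%. The change from compound 2 to compound 1 is methoxy in place of methyl on an aromatic carbon, and it made a number 7 percentage points higher from compound 2 to compound 1 (within the scatter). Compound 3 stands highest of the three; its core differs from that of compound 2 by 2-methylphenyl in place of 3-methylphenyl on a saturated chain carbon bound to an amide-type nitrogen, a step of a number 25 percentage points higher from compound 2 to compound 3 (beyond the scatter).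

Compound 4 `CCN(Cc1ccccc1OC)C(=O)C1CCN(S(=O)(=O)c2ccc3cn[nH]c3c2)CC1` is not yet measured. It differs from compound 3 by methoxy in place of methyl on an aromatic carbon. For the measured compounds named here, this is the same kind of change as the one from compound 2 to compound 1, but the place is not the same: there the group sits meta to a large group, here ortho to a large group. The earlier step, a number 7 percentage points higher from compound 2 to compound 1 (within the scatter), stayed within the scatter. A similarly small step is therefore expected here, a number 3 percentage points higher from compound 3 to compound 4 (within the scatter). Compound 4 is estimated at 106% in this assay, with a likely range from 90% to 122%.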

Compound 4, largest response reached (reported as percent of maximum), in percent of the reference or control that the assay uses: 92%
Compound 4: the middle estimate sits 14 percentage points above what was measured; the range from low to high includes it.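

Methoxy in place of methyl gave a number 11 percentage points lower from compound 3 to compound 4 (beyond the scatter), so the change did not carry over unchanged from the core of compound 2 to the core of compound 3: the same change on two cores in this assay, a number 7 percentage points higher (within the scatter) from compound 2 to compound 1 and a number 11 percentage points lower (beyond the scatter) from compound 3 to compound 4, 18 percentage points apart, beyond the scatter of two such steps
Replacing the ring group of the other compounds with 2-methoxyphenyl gave a number 14 percentage points higher from compound 2 to compound 4 (beyond the scatter) and a number 7 percentage points higher from compound 1 to compound 4 (within the scatter), so only the first of these two steps lies beyond the scatter. This rests on just two pairs, so it shows that the outcome of this swap in this assay depends on the core it is made on, but it does not explain why the two steps differ or predict the step on any further core.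

The compounds shown leave open how an ethoxy group, a chlorine atom or an amino group would behave in place of the methyl of compound 3. They also leave open whether a propyl chain in place of the ethyl on the amide nitrogen would change the maximal response.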